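Freeing a Protected Hydroxyl: Expected Effect on Cell Growth

A few compounds are considered here, and "the series" means these few. Any claim that something is new, unique, unknown or untested is made for them only; others in the source may bear on it.

Measured in a functional assay on WiDr cells (Homo sapiens) for antiproliferative activity, read by sulforhodamine B assay, with a stated time of 48 h; on this read-out higher numbers stand for weaker inhibition of growth and lower numbers for stronger inhibition of growth:
Compound 1 `CC(C)(C)[Si](C)(C)O[C@@H]1CCCO[C@@H]1/C=C/C(=O)OCc1ccccc1`: 90000 nM
Compound 2 `O=C(/C=C/[C@H]1OCCC[C@H]1O)OCc1ccccc1`: a limit of the assay, > 100000 nM
Compound 3 `CC(C)(C)[Si](C)(C)O[C@@H]1CCCO[C@@H]1CC(=O)OCc1ccccc1`: 19000 nM

Compound 1 and compound 2 differ by one change, (a hydrogen atom in place of a group of 7 heavy atoms (6 carbon, 1 silicon; no ring), on an oxygen on a saturated carbon). The step is an at least 1.1-fold higher number from compound 1 to compound 2 (0.04 log units; that floor lies within the scatter); the size of this step is only a floor, because compound 2 sits at the limit of > 100000 nM in this assay, at which 1 of the 3 values shown sits. How the core of compound 3 differs from the core of compound 1 is not broken down here; the two values show that compound 3 gives the lowest number of the two.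

Compound 4 `O=C(C[C@H]1OCCC[C@H]1O)OCc1ccccc1` is not yet measured. It differs from compound 3 by a hydrogen atom in place of a group of 7 heavy atoms (6 carbon, 1 silicon; no ring), on an oxygen on a saturated carbon, the same change as that from compound 1 to compound 2, at a place described in the same words. The expected step is a 3.2-fold higher number from compound 3 to compound 4 (0.50 log units; beyond the scatter), resting on the earlier step, an at least 1.1-fold higher number from compound 1 to compound 2 (0.04 log units; that floor lies within the scatter), which moved the number upward, so a weakening of growth inhibition is expected for compound 4. Compound 4 is thus estimated at 60000 nM, with an expected range from 25000 nM to 120000 nM, and it may also reach the limit of this assay.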

Compound 4, concentration for 50% growth inhibition: > 100000 nM
Compound 4 gave a limit, no number (the forecaster's own chance of this, stated with the estimate: 30%); middle value at least 1.6-fold (0.22 log units) from the limit.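

In this assay, a hydrogen atom in place of the group of 7 heavy atoms (6 carbon, 1 silicon) on the oxygen gives an at least 5.2-fold higher number from compound 3 to compound 4 (0.72 log units; beyond the scatter), a weakening of growth inhibition that lies beyond the scatter. Going by these compounds, compound 4 gives > 100000 nM, which is a limit of the assay and not a number, so the true size of this step remains unknown. The same change thus makes a clear difference on this second core, but this does not show that it acts to the same extent on both cores: the same change on two cores in this assay, an at least 1.1-fold higher number (0.04 log units; that floor lies within the scatter) from compound 1 to compound 2 and an at least 5.2-fold higher number (0.72 log units; beyond the scatter) from compound 3 to compound 4; the limit leaves it open whether they differ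

The compounds shown leave open whether a smaller group on this oxygen, such as methyl or acetyl, would keep more growth inhibition than the free hydroxyl does. They also leave open how the change would behave with a carboxylic acid or an amide in place of the ester.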